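From Chloro to Trifluoromethyl on the Benzylic Ring

This account rests on a few compounds, and the source may have more. Where it says the series, first, only, none or still open, it means among the compounds named here.

Two compounds have been measured in a functional assay for antagonist activity at transient receptor potential cation channel subfamily V member 1 (Homo sapiens), read by calcium flux; on this read-out higher numbers stand for weaker inhibition and lower numbers for stronger inhibition:

Compound 1, `O=C(NCc1ccc(N2CCCCCC2)cc1)Nc1cccc2cnccc12`, gives 3.3 nM.
Compound 2, `O=C(NCc1ccc(N2CCCCCC2)cc1Cl)Nc1cccc2cnccc12`, gives 5.2 nM.

Compound 2 has the higher of the two numbers, but the step of a 1.6-fold higher number from compound 1 to compound 2 (0.20 log units; within the scatter) is within the scatter, so compound 1 and compound 2 cannot be told apart on this read-out. Compound 3, `O=C(NCc1ccc(N2CCCCCC2)cc1C(F)(F)F)Nc1cccc2cnccc12`, has not yet been measured. It differs from compound 2 by trifluoromethyl in place of chloro on an aromatic carbon. Within the data shown here, only one measured step bears on this site: from compound 1 to compound 2 a hydrogen was exchanged for chloro at the same aromatic carbon, and that step was a 1.6-fold higher number from compound 1 to compound 2 (0.20 log units; within the scatter). Among the measured compounds shown here, a further exchange at the same place, replacing chloro with trifluoromethyl, has no measured precedent here. Given that the one known change at this carbon stayed within the scatter, compound 3 is expected to give a number close to that of compound 2, with a step of a 1.3-fold higher number from compound 2 to compound 3 (0.13 log units; within the scatter) that is estimated to remain within the scatter. The estimate for compound 3 in this assay is 7 nM, with a range from 2.5 nM to 20 nM.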

Compound 3, half-maximal inhibitory concentration: 5.7 nM
The estimate for compound 3 lay 1.2-fold (0.09 log units) above the measured number, and the stated range covers the measured number.
By their numbers in this assay, from the lowest: compounds 1, 2 and 3 (each within the scatter of the next).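

In this assay, among these compounds, the earlier compounds showed only that chloro could stand in place of hydrogen on this aromatic carbon; the new result adds that trifluoromethyl, with 4 heavy atoms where chloro has 1, also stays within the scatter, with a 1.1-fold higher number from compound 2 to compound 3 (0.04 log units; within the scatter). Set against the hydrogen of the parent, the exchange gives a 1.7-fold higher number from compound 1 to compound 3 (0.24 log units; within the scatter), so hydrogen, chloro and trifluoromethyl at this place, in compound 1, compound 2 and compound 3, cannot be told apart on this read-out, and the larger group opens no measurable gap. No measurement at hand offers any account of why the number stays so flat across these groups.

Chloro and trifluoromethyl both count no hydrogen-bond donors and no hydrogen-bond acceptors, so it remains open whether an amine, a carboxylic acid or a longer chain on the same carbon would keep the number within the scatter as well. As far as these compounds go, it is also open whether the same exchanges would stay as flat with something other than the azepan-1-yl group on the ring, such as a smaller piperidine or an open-chain amine.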